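Benzylcarbamoyl in place of benzyl: working notes

The source may report more compounds than this note shows. Statements on the series, on what has been measured and on what is new or still open speak of the compounds shown alone.

In a functional assay on MDA-MB-231 cells (Homo sapiens) for antiproliferative activity, read by MTT assay, with a stated time of 72 h (a lower number here means a stronger inhibitor, a higher number a weaker inhibitor), compound 2 `CC1=CC[C@H]2[C@H](CC[C@]2(C)O)C(C)(C)[C@@H]1CC[C@H]1[C@]2(C)CC[C@H](OCc3ccccc3)C(C)(C)O[C@H]2CC[C@@]1(C)O` gives 29100 nM, within the scatter of compound 1 `CC1=CC[C@H]2[C@H](CC[C@]2(C)O)C(C)(C)[C@@H]1CC[C@H]1[C@]2(C)CC[C@H](OC(=O)c3ccc(C)cc3)C(C)(C)O[C@H]2CC[C@@]1(C)O` at 33400 nM. Compound 3 `CC1=CC[C@H]2[C@H](CC[C@]2(C)O)C(C)(C)[C@@H]1CC[C@H]1[C@]2(C)CC[C@H](OC(=O)NCc3ccccc3)C(C)(C)O[C@H]2CC[C@@]1(C)O` carries this change: benzylcarbamoyl in place of benzyl on an oxygen on a saturated carbon. In words, benzylcarbamoyl replaces benzyl on an oxygen on a saturated carbon. For the measured compounds named here, one measured step bears on it, benzyl in place of (4-methylphenyl)carbonyl on that oxygen: a 1.1-fold lower number from compound 1 to compound 2 (0.06 log units; within the scatter), within the scatter. No step beyond the scatter is therefore expected in this assay. The expected step is a 1.1-fold lower number from compound 2 to compound 3 (0.03 log units; within the scatter). Compound 3 is expected at 27000 nM, with an estimated range of 13000 nM to 50000 nM.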

Compound 3, half-maximal inhibitory concentration: 40300 nM
The estimate for compound 3 lay 1.5-fold (0.17 log units) below the measured number; the range from low to high includes it.
By their numbers in this assay, from the lowest: compounds 2, 1 and 3 (each within the scatter of the next).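

Benzylcarbamoyl on an oxygen on a saturated carbon brings a nitrogen and a hydrogen-bond donor to this place, yet in this assay it gives a 1.4-fold higher number from compound 2 to compound 3 (0.14 log units; within the scatter), and benzylamino in place of 4-methylphenyl on a carbonyl carbon gives a 1.2-fold higher number from compound 1 to compound 3 (0.08 log units; within the scatter). Both steps lie within the scatter, so the three groups on this oxygen do not separate in this assay. Nothing available explains this result.

From the compounds shown here alone, whether a free hydroxyl, an amine or a carboxylic acid at this place would give a step beyond the scatter remains open. Going by these compounds, the effect of changes elsewhere on the shared core also remains open.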